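The compounds below may be only part of what the source reports. "The series", "measured", "known", "first", "only" and "open" are said of these compounds alone.

Measured so far in a functional assay on K562 cells (Homo sapiens) for cytotoxicity, read by MTT assay, with a stated time of 72 h; on this read-out higher numbers stand for weaker inhibition and lower numbers for stronger inhibition:
- Compound 1 `COCOc1cc(/C=C/C(=O)OCC(=O)Nc2ccc(OC)cc2)ccc1OCc1ccccc1` gives > 200000 nM, a limit of the assay rather than a number.
- Compound 2 `COc1ccc(NC(=O)COC(=O)/C=C/c2cc(OC)c(OCc3ccc(Cl)c(Cl)c3)c(OC)c2)cc1` gives > 200000 nM, likewise a limit.
- Compound 3 `CCOc1ccc(COc2c(OC)cc(/C=C/C(=O)OCC(=O)Nc3ccccc3)cc2OC)cc1` gives > 200000 nM, likewise a limit.

Compound 2 therefore stands nowhere in particular on the numbers shown: its value is a limit, and the limit of > 200000 nM in this assay, at which 3 of the 3 values shown sit, means that every value in this assay so far is the same limit, so no ordering among compound 1, compound 2 and compound 3 can be read from them. Among the measured compounds shown here, no pair of measured compounds differs in one place only, so no measured step is available in this assay.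

The unmeasured compound 4 `COc1ccc(NC(=O)COC(=O)/C=C/c2cc(OC)c(OCc3ccccc3)c(OC)c2)cc1` is reached from compound 2 by a single change: phenyl in place of 3,4-dichlorophenyl on a saturated chain carbon bound to an oxygen on an aromatic ring. Compound 1 carries the same benzyloxy group, but differs from compound 2 at other places as well, so the two only show that both sit at the limit.

Expectation in this assay: no step beyond the scatter, in either direction. The step this estimate means, a step that the limit leaves unreadable from compound 2 to compound 4, is expected to be none beyond the scatter. Compound 4 is expected to come out at the limit again, with an estimate of 300000 nM and a range from 120000 nM to 1000000 nM.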

Compound 4, half-maximal inhibitory concentration: > 200000 nM
Compound 4: only a limit was reported; the forecaster's own chance of this, stated with the estimate: 85%; the middle value is on the limit's open side.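

In this assay compound 4 gives > 200000 nM as a limit and not a number. No new step can be read between compound 2 and compound 4, since both sit at the same limit: the limit of > 200000 nM in this assay, at which 4 of the 4 values shown sit. The compounds shown leave open whether any member of this series reaches a measurable value in this assay and whether phenyl in place of 3,4-dichlorophenyl changes anything there.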